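The compounds below may be only part of what the source reports. "The series", "measured", "known", "first", "only" and "open" are said of these compounds alone.

Three related compounds have been measured in a functional assay on a cell-free system (plasma, Homo sapiens), with a stated time of 3 min; on this read-out higher numbers stand for weaker inhibition and lower numbers for stronger inhibition. In this assay, compound 1 `O=C(NCc1cc(Cl)ccc1-n1cnnn1)[C@@H]1CC=NN1C(=O)[C@H](O)c1ccccc1` gives 840 nM, compound 3 `O=C(NCc1cc(Cl)ccc1-n1cnnn1)[C@@H]1CCNN1C(=O)[C@H](O)c1ccccc1` gives 930 nM and compound 2 `O=C([C@H](O)c1ccccc1)N1CC[C@@H]2C[C@@]21C(=O)NCc1cc(Cl)ccc1-n1cnnn1` gives 1100 nM. These numbers lie within the usual scatter of repeated measurements, so compound 1 stands level with the other two. Compound 4 `CCCC[C@@H](O)C(=O)N1N=CC[C@H]1C(=O)NCc1cc(Cl)ccc1-n1cnnn1` keeps the core of compound 1 and alters one group: butyl in place of phenyl on a saturated chain carbon bound to a carbonyl carbon and an oxygen on a saturated carbon. Put simply, it has butyl in place of phenyl on a saturated chain carbon bound to a carbonyl carbon and an oxygen on a saturated carbon. All three measured compounds carry the phenyl, so none of them shows directly what replacing it does. With compound 1 at 840 nM as the starting point, a moderate step toward a higher number, meaning weaker inhibition, is expected in this assay, though the uncertainty is wide. The expected change is a 3.0-fold higher number from compound 1 to compound 4 (0.47 log units; beyond the scatter). The estimated value for compound 4 is 2500 nM, within an expected range of 800 nM to 8000 nM.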

Compound 4, half-maximal inhibitory concentration in the Homo sapiens assay: 610 nM
Compound 4: the middle estimate sits 4.1-fold (0.61 log units) above what was measured; the measured number lies below the stated range.
By their numbers in the Homo sapiens assay, from the lowest: compounds 4, 1, 3 and 2 (each within the scatter of the next).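

In the Homo sapiens assay, compound 1 gives 840 nM and compound 4 gives 610 nM with butyl in place of phenyl on this saturated chain carbon, which is a 1.4-fold lower number from compound 1 to compound 4 (0.14 log units; within the scatter), so the two stand level and an aromatic ring at this position is not required to hold inhibition at this level. In a physicochemical assay for solubility, measured as kinetic solubility, at pH 6.8 (a lower number here means a less soluble compound, a higher number a more soluble compound), compound 1 gives 98000 nM and compound 4 gives 59000 nM with the same change, which is a 1.7-fold lower number from compound 1 to compound 4 (0.22 log units; within the scatter), so the two also stand level for solubility. Nothing available explains why phenyl and butyl perform alike at this position.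

The compounds shown leave open how far this position tolerates other groups, and whether a longer chain, an amine or a carboxylic acid on the same carbon would move either read-out beyond the scatter. From the compounds shown here alone, whether butyl would behave the same way on the cores of compound 2 and compound 3 also remains open.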